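Swapping a methyl for a carboxy on the aryl amine

The compounds below may be only part of what the source reports. "The series", "measured", "known", "first", "only" and "open" are said of these compounds alone.

Compound 1 `Cc1cccc(C)c1Nc1nc2c(Nc3ccc(C(F)(F)F)cc3)ncnc2s1`: 23 nM
Compound 2 `Cc1ccc(Nc2ncnc3sc(Nc4c(Cl)cccc4Cl)nc23)cc1`: 33 nM

Of the compounds shown here, two on the shared core have been measured in a functional assay on HEK293 cells for antagonist activity at transient receptor potential cation channel subfamily V member 1 (Homo sapiens), read by calcium flux; on this read-out lower numbers stand for stronger inhibition and higher numbers for weaker inhibition. Compound 1 gives 23 nM there, and compound 2 gives 33 nM. Compound 2 holds the higher of the two numbers, but its gap to compound 1 lies within the scatter, so the two values show no ordering. Among the measured compounds shown here, no pair among the measured compounds differs in a single place, so no step of this kind has been seen yet.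

Compound 3 `O=C(O)c1ccc(Nc2ncnc3sc(Nc4c(Cl)cccc4Cl)nc23)cc1` departs from compound 2 in one position: carboxy in place of methyl on an aromatic carbon. Read one bond further out, a 4-methylphenyl becomes a 4-carboxyphenyl. With nothing measured to anchor it, the step from compound 2 to compound 3 is expected to run toward a weaker number, by a margin that reaches beyond the scatter, at a 15-fold higher number from compound 2 to compound 3 (1.18 log units; beyond the scatter). For compound 3 the estimate in this assay is therefore 500 nM, with a range from 80 nM to 5000 nM.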

Compound 3, half-maximal inhibitory concentration: > 5000 nM
Compound 3 ended at the assay's limit (the forecaster's own chance of this, stated with the estimate: 20%); middle value at least 10-fold (1.00 log units) away from the limit.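

Among the compounds shown here, this is the first step on the shared core that differs in a single place, and it shows that the position holding the methyl does not accept every group: in this assay, carboxy in place of methyl on an aromatic carbon gives an at least 150-fold higher number from compound 2 to compound 3 (2.18 log units; beyond the scatter), well beyond the scatter. Compound 3 reads > 5000 nM, which is a limit of the assay and not a number. The step therefore has a lower bound but no measured size: the limit of > 5000 nM in this assay, at which 1 of the 3 values shown sits.

The compounds shown leave open whether a methyl ester, a primary amide or a hydroxymethyl at this position would stay close to compound 2 or fall as far as compound 3. Going by these compounds, whether a carboxylic acid in place of the trifluoromethyl of compound 1 would carry the same cost also remains open.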